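The compounds below may be only part of what the source reports. "The series", "measured", "known", "first", "only" and "open" are said of these compounds alone.

Among the compounds with values here, compound 3 `Cc1nc(C)n(CC(=O)N2CCN(c3sc(C(F)(F)F)nc3-c3nc4ccccc4[nH]3)C[C@H]2C)n1` gives 3.3 in a physicochemical assay for lipophilicity, at pH 7.4 (a higher number here means a more lipophilic compound, a lower number a more polar compound), the lowest of the three numbers so far; compound 1 `Cc1nc(C)n(CC(=O)N2CCN(c3sc(C(F)(F)F)nc3-c3nc4c(F)cccc4[nH]3)C[C@H]2C)n1` gives 3.6, and compound 2 `Cc1nc(C)n(CC(=O)N2CCN(c3sc(C(F)(F)F)nc3-c3nc4ccc(C5CCOCC5)cc4[nH]3)C[C@H]2C)n1` gives 3.7. The step of a number 0.30 log units lower from compound 1 to compound 3 (within the scatter) lies within the scatter, whereas the step of a number 0.40 log units lower from compound 2 to compound 3 (beyond the scatter) lies beyond it. Compound 4 `Cc1nc(C)n(CC(=O)N2CCN(c3sc(C(F)(F)F)nc3-c3nc4ccc(C5CCN(C)CC5)cc4[nH]3)C[C@H]2C)n1` carries the change (1-methylpiperidin-4-yl in place of hydrogen on an aromatic carbon). Within the data shown here, only the step from compound 2 bears on this, through its six-membered ring with one hetero atom; no measured step covers 1-methylpiperidin-4-yl itself, so the direction rests on a single comparison and the range is kept wide. For compound 4 a value of 2.7 is estimated in this assay, between 1.9 and 3.5. This means an expected step of a number 0.60 log units lower from compound 3 to compound 4 (beyond the scatter).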

Compound 4, distribution coefficient: 3.4
Compound 4: the middle estimate sits 0.70 log units below what was measured; low and high end bracket the measured number.
By their numbers in this assay, from the lowest: compounds 3, 4, 1 and 2 (each within the scatter of the next, the first and the last beyond it).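

In this assay, 1-methylpiperidin-4-yl on this aromatic carbon gives a number 0.10 log units higher from compound 3 to compound 4 (within the scatter), so this larger group leaves the number indistinguishable from that with hydrogen, whereas the oxan-4-yl comparison gave a number 0.40 log units lower from compound 2 to compound 3 (beyond the scatter). Exchanging one six-membered ring for the other gives a number 0.30 log units lower from compound 2 to compound 4 (within the scatter), so the two substituents are not separated in this assay either. No available evidence accounts for this result.

From the compounds shown here alone, whether a carboxylic acid or an open-chain amine on this aromatic carbon would shift the number beyond the scatter remains open. So does the effect of 1-methylpiperidin-4-yl at other aromatic carbons of the shared core.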